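From iodo to methoxy: working notes on compound 3

The source may hold more compounds than are shown below. What is called first, only, known or untested is meant among the compounds shown, and "the series" means these compounds.

In a functional assay on PC-3 cells (Homo sapiens) for inhibition (on this read-out lower numbers stand for stronger inhibition of growth and higher numbers for weaker inhibition of growth), compound 2 (`NC(=O)c1cc(I)ccc1NC(=O)COc1ccccc1`) gives 428 nM as the lowest of two numbers, and compound 1 (`NC(=O)c1cc(Cl)ccc1NC(=O)COc1ccccc1`) gives 3220 nM as the higher one. Compound 3 (`COc1ccc(NC(=O)COc2ccccc2)c(C(N)=O)c1`) carries methoxy in place of iodo on an aromatic carbon. The change is methoxy in place of iodo on an aromatic carbon and sits para to a large group. Among the measured compounds shown here, only one measured step bears on this place, a 7.5-fold lower number from compound 1 to compound 2 (0.88 log units; beyond the scatter) for iodo in place of chloro, and it lies beyond the scatter. For the measured compounds named here, no measured compound carries methoxy. A somewhat smaller step back upward in this assay is expected, with wide margins. The estimated step is a 4.7-fold higher number from compound 2 to compound 3 (0.67 log units; beyond the scatter) on present data. Compound 3 is estimated at 2000 nM within a range of 600 nM to 7000 nM for now.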

Compound 3, concentration for 50% growth inhibition: 464 nM
Compound 3: middle estimate off by 4.3-fold (0.63 log units), on the high side; measured number below the stated range.
By their numbers in this assay, from the lowest: compounds 2 and 3 (each within the scatter of the next); then compound 1.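

In this assay the move to methoxy gives a 1.1-fold higher number from compound 2 to compound 3 (0.04 log units; within the scatter) and so the level of compound 2 at this place, para to a large group, does not depend on iodo. Methoxy in place of chloro gives a 6.9-fold lower number from compound 1 to compound 3 (0.84 log units; beyond the scatter) and so, of the three groups, only chloro stands apart, with compound 1 at the higher number. Nothing available here explains this result.

Open, from the compounds shown here alone, is whether other groups at this place, such as an amine, a hydroxy group or a longer alkoxy chain, stay at the level of compound 2 and compound 3.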